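Methoxy added to the anilide of compound 3

The source may hold more compounds than are shown below. What is called first, only, known or untested is meant among the compounds shown, and "the series" means these compounds.

Compound 1 `COc1ccc(Cl)cc1N(CC(=O)N1CCc2ccccc21)S(=O)(=O)c1ccccc1` shows in a functional assay on SH-SY5Y cells (Homo sapiens), read by MTT assay, with a stated time of 24 h (on this read-out higher numbers stand for an effect only at larger amounts of compound and lower numbers for an effect already at smaller amounts), a limit, > 20000 nM.
Compound 2 `COc1ccc(Cl)cc1N(CC(=O)N1CCCCC1)S(=O)(=O)c1ccccc1` shows in this assay 14500 nM.
Compound 3 `COc1ccc(Cl)cc1N(CC(=O)Nc1ccccc1)S(=O)(=O)c1ccccc1` shows in this assay a limit, > 20000 nM.

Compound 3 thus stands at the edge of what this assay reports: its value is a limit, not a number, and it shares that position with compound 1 (the limit of > 20000 nM in this assay, at which 2 of the 3 values shown sit). The step that the two limits leave unreadable from compound 1 to compound 3 cannot be read, and the step of an at least 1.3-fold higher number from compound 2 to compound 3 (0.13 log units; that floor lies within the scatter) carries only a floor, while the step of an at least 1.3-fold lower number from compound 1 to compound 2 (0.13 log units; that floor lies within the scatter) likewise carries a floor. Compound 4 `COc1cccc(NC(=O)CN(c2cc(Cl)ccc2OC)S(=O)(=O)c2ccccc2)c1` differs from compound 3 in one place: methoxy in place of hydrogen on an aromatic carbon. Going by the values given here, none of the measured steps touches the anilide ring itself; all three exchange the whole amide substituent. Among the compounds with values here, there is therefore no measured step that bears directly on this change, and compound 3 offers only a limit as a starting point. The expectation is that compound 4 stays near that limit, with the step that the limit leaves unreadable from compound 3 to compound 4 expected to be no more than the scatter. For compound 4 the estimated value is 25000 nM, within 8000 nM to 80000 nM.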

Compound 4, half-maximal effective concentration: 17600 nM
For compound 4 the middle estimate is 1.4-fold (0.15 log units) above the measured one; the measured number falls inside the stated range.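

Compound 4, with (3-methoxyphenyl)amino on the carbonyl carbon, gives a number in this assay, 17600 nM, so this change yields a readable value for an anilide. Compound 3 has only a limit, so the methoxy change can be read only as an at least 1.1-fold lower number from compound 3 to compound 4 (0.05 log units; that floor lies within the scatter), a floor and not a full size: the limit of > 20000 nM in this assay, at which 2 of the 4 values shown sit. The number for compound 4 also gives a 1.2-fold higher number from compound 2 to compound 4 (0.08 log units; within the scatter) and an at least 1.1-fold lower number from compound 1 to compound 4 (0.05 log units; that floor lies within the scatter), so the anilide with methoxy shows no separation beyond the scatter from the piperidin-1-yl amide, while its distance from the 2,3-dihydro-1H-indol-1-yl amide has only a floor.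

As far as these compounds go, how far methoxy truly moves the value from the plain anilide stays open. Also open, from the compounds shown here alone, is whether an amine or a carboxylic acid on this ring would give a step beyond the scatter.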